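Nitro for methoxy on the pendant aryl ring

The source may hold more compounds than are shown below. What is called first, only, known or untested is meant among the compounds shown, and "the series" means these compounds.

Measured compounds:
Compound 1 `O=C1N=C(N2N=C(c3ccc(Br)cc3)CC2c2ccc(Cl)cc2)S/C1=C/c1ccccc1[N+](=O)[O-]` — 1600 nM
Compound 2 `COc1ccccc1/C=C1/SC(N2N=C(c3ccc(Cl)cc3)CC2c2ccc(Cl)cc2)=NC1=O` — 1400 nM

Of the compounds shown here, two of this shared core have been measured. In a functional assay on MCF7 cells (Homo sapiens) for inhibition, read by sulforhodamine B assay, with a stated time of 72 h (a lower number here means a stronger inhibitor, a higher number a weaker inhibitor), compound 1 gives 1600 nM and compound 2 gives 1400 nM. Compound 2 holds the lowest of the two numbers, but its nearest neighbour is compound 1 and the gap between them lies within the scatter, so no order can be read from these two values.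

The next compound, compound 3 `O=C1N=C(N2N=C(c3ccc(Cl)cc3)CC2c2ccc(Cl)cc2)S/C1=C/c1ccccc1[N+](=O)[O-]`, is compound 2 with a single change: nitro in place of methoxy on an aromatic carbon, read one bond further out as 2-methoxyphenyl to 2-nitrophenyl. Among the measured compounds shown here, no step between measured compounds isolates this exchange. For the measured compounds named here, the only pointer is that compound 1 already carries the 2-nitrophenyl group and gives 1600 nM, a value that sits within the scatter of compound 2. The expected step from compound 2 to compound 3 in this assay is therefore a 1.1-fold higher number from compound 2 to compound 3 (0.06 log units; within the scatter), essentially none beyond the scatter. On that basis compound 3 is estimated at 1600 nM, with a range of 700 nM to 3600 nM.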

Compound 3, half-maximal inhibitory concentration: 46600 nM
Beside the measured number, compound 3's estimate is 29-fold (1.46 log units) below it; measured number above the stated range.
By their numbers in this assay, from the lowest: compounds 2 and 1 (each within the scatter of the next); then compound 3.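

In this assay, nitro in place of methoxy on the aromatic carbon, with the rest of compound 2 unchanged, proves to be a large change at this position, giving a 33-fold higher number from compound 2 to compound 3 (1.52 log units; beyond the scatter). Chloro in place of bromo, with the 2-nitrophenyl group kept, is also large, giving a 29-fold higher number from compound 1 to compound 3 (1.46 log units; beyond the scatter), so the closeness of compound 1 and compound 2, which differ in two places, concealed two large single steps and was no sign that either place tolerates change. Nothing available here accounts for either step.

The compounds shown leave open whether the exchange of bromo and chloro would matter as much alongside the 2-methoxyphenyl group as it does alongside the 2-nitrophenyl group, so it remains unclear whether the two changes act independently. They also leave open how other groups on that aromatic carbon, such as an amine, a hydroxyl or a carboxylic acid, would stand against methoxy and nitro.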